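Swapping 3,5-dimethoxyphenyl for 3-aminophenyl on the shared core

The compounds below may be only part of what the source reports. "The series", "measured", "known", "first", "only" and "open" are said of these compounds alone.

Compound 1 (`Nc1cccc(Nc2nc3ccccc3nc2S(=O)(=O)c2ccccc2)c1`) gives 4290 nM in a functional assay on KB cells (Homo sapiens) for cytotoxicity, read by MTT assay, with a stated time of 72 h; on this read-out higher numbers stand for weaker inhibition and lower numbers for stronger inhibition
Compound 2 (`COc1cc(Nc2nc3ccccc3nc2S(=O)(=O)c2ccc(C)cc2)cc(OC)c1`) gives "not determined" (no result reported) in this assay

Compound 2 thus stands without a single number and sets no baseline. Compound 3 (`Cc1ccc(S(=O)(=O)c2nc3ccccc3nc2Nc2cccc(N)c2)cc1`) awaits measurement. The structural change (3-aminophenyl in place of 3,5-dimethoxyphenyl on a nitrogen on an aromatic ring) puts 3-aminophenyl in place of 3,5-dimethoxyphenyl on a nitrogen on an aromatic ring. No size or direction of step can be read from compound 2, so compound 3 is expected in this assay to lie within the usual scatter of compound 1 (4290 nM). For compound 3 the estimated value is 3500 nM (range 1200 nM to 10000 nM).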

Compound 3, half-maximal inhibitory concentration: 10600 nM
For compound 3 the middle estimate is 3.0-fold (0.48 log units) below the measured one, outside the stated range (above it).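

With 3-aminophenyl held on the nitrogen, methyl in place of hydrogen on an aromatic carbon gives a 2.5-fold higher number from compound 1 to compound 3 (0.39 log units; beyond the scatter) in this assay and so shows that this single added methyl moves the read-out beyond the usual scatter. The swap of 3,5-dimethoxyphenyl for 3-aminophenyl remains unreadable, as compound 2 has no number to compare. Nothing shown here gives a cause for the methyl step. Open, going by these compounds, is whether a chlorine, a methoxy group or an ethyl group at that aromatic carbon would give a similar step.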